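Nitro to chloro on the sulfonyl aryl ring

A few compounds are considered here, and "the series" means these few. Any claim that something is new, unique, unknown or untested is made for them only; others in the source may bear on it.

Measured so far in a functional assay on HeLa cells (Homo sapiens) for antiproliferative activity, read by MTT assay, with a stated time of 24 h; on this read-out lower numbers stand for stronger inhibition and higher numbers for weaker inhibition:
compound 1 `FC(F)(F)c1ccc(-c2nn(-c3ccccc3)cc2-c2nc3ccccc3[nH]2)cc1` gives 4670 nM
compound 2 `O=S(=O)(c1ccc(Cl)cc1)n1c(-c2cn(-c3ccccc3)nc2-c2ccc(F)cc2)nc2ccccc21` gives 3450 nM
compound 3 `O=[N+]([O-])c1ccc(S(=O)(=O)n2c(-c3cn(-c4ccccc4)nc3-c3ccc(C(F)(F)F)cc3)nc3ccccc32)cc1` gives 950 nM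

Compound 3 has the lowest number of the three, beyond the scatter of both others. Compound 4 (`O=S(=O)(c1ccc(Cl)cc1)n1c(-c2cn(-c3ccccc3)nc2-c2ccc(C(F)(F)F)cc2)nc2ccccc21`) carries chloro in place of nitro on an aromatic carbon, para to a large group (chloro in place of nitro on an aromatic carbon). Among the measured compounds shown here, the one measured step, a 4.9-fold lower number from compound 1 to compound 3 (0.69 log units; beyond the scatter), introduces the (4-nitrophenyl)sulfonyl group and is modest. For the measured compounds named here, no measured step isolates this swap. Compound 2, which has the (4-chlorophenyl)sulfonyl group but differs elsewhere, gives 3450 nM and so points to a modest rise in this assay. The estimated change is a 1.9-fold higher number from compound 3 to compound 4 (0.28 log units; within the scatter) in size. Compound 4 is expected at 1800 nM, within an estimated range of 800 nM to 4000 nM.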

Compound 4, half-maximal inhibitory concentration: 3060 nM
Compound 4: middle estimate off by 1.7-fold (0.23 log units), on the low side; the measured number falls inside the stated range.
By their numbers in this assay, from the lowest: compound 3; then compounds 4, 2 and 1 (each within the scatter of the next).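

In this assay, the lower number of compound 3 depends on the nitro group and not on the sulfonyl link alone: chloro in place of nitro on this ring reverses much of the gain (a 3.2-fold higher number from compound 3 to compound 4 (0.51 log units; beyond the scatter)). With (4-chlorophenyl)sulfonyl on the aromatic nitrogen, the value stays within the scatter of the free nitrogen (a 1.5-fold lower number from compound 1 to compound 4 (0.18 log units; within the scatter)). Trifluoromethyl in place of fluoro also stays within the scatter when chloro is present (a 1.1-fold lower number from compound 2 to compound 4 (0.05 log units; within the scatter)). Going by these compounds, an amine or a nitrile on this ring remains open, as does the fluoro partner of compound 3. No evidence accounts for the nitro-chloro difference.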